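A Nitro Swap at the Limit of Tolerance

This account rests on a few compounds, and the source may have more. Where it says the series, first, only, none or still open, it means among the compounds named here.

In an ADME assay on MDCK cells (Canis lupus familiaris) for cytotoxicity, read by MTT assay, with a stated time of 48 h (a lower number here means that less compound is tolerated, a higher number that more compound is tolerated), three compounds have been read so far, and none of them gives a number. Compound 1 (`O=C(Nc1nc2nc(-c3ccccc3)ccn2n1)c1ccccc1`) reads > 250000 nM as a limit of the assay. Compound 3 (`Cc1cc(-c2ccccc2)nc2nc(C(=O)Nc3ccccc3F)nn12`) reads > 250000 nM, again a limit. Compound 2 (`Cc1cc(-c2ccccc2)nc2nc(NC(=O)c3ccccc3F)nn12`) reads > 250000 nM, so its standing too is known only as a limit. The set as a whole shows the limit of > 250000 nM in this assay, at which 3 of the 3 values shown sit, and offers no measured step to reason from.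

Compound 4 (`Cc1cc(-c2ccccc2)nc2nc(NC(=O)c3ccc([N+](=O)[O-])cc3)nn12`) departs from compound 2 by carrying 4-nitrophenyl in place of 2-fluorophenyl on a carbonyl carbon. The expectation therefore rests on compound 2 and its limit of > 250000 nM alone. The step of a number no higher from compound 2 to compound 4 (the limit leaves the size open) is expected to be none beyond the scatter, and any shift that does appear is expected toward less compound tolerated. Compound 4 is estimated at 250000 nM with an expected range of 120000 nM to 250000 nM and may well return only a limit once more.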

Compound 4, half-maximal cytotoxic concentration: > 250000 nM
Compound 4: no number, only a limit; the forecaster's own chance of this, stated with the estimate: 75%; the middle value sits exactly at the limit.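

Compound 2 and compound 4 both stand only as limits in this assay, so no step can be read between them. The compounds shown leave open whether any of them differs from another in the cells, for all share one result: the limit of > 250000 nM in this assay, at which 4 of the 4 values shown sit.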